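Working notes on a three-compound series

The source may hold more compounds than are shown below. What is called first, only, known or untested is meant among the compounds shown, and "the series" means these compounds.

Measured in an assay on mitochondria (strain BALB/c) for inhibition of glycerol-3-phosphate acyltransferase 1, mitochondrial (Mus musculus), read by scintillation counting, with a stated time of 10 min; on this read-out higher numbers stand for weaker inhibition and lower numbers for stronger inhibition:
compound 1 `CCCCCCCCS(=O)(=O)Nc1ccc(-c2ccccc2OC)cc1C(=O)O` gives 27600 nM
compound 2 `CCCCCCCCS(=O)(=O)Nc1ccc(-c2cccc(F)c2)cc1C(=O)O` gives 37600 nM

Within the data shown here, compound 2 holds the higher of the two numbers so far, and its nearest neighbour is compound 1; the step of a 1.4-fold higher number from compound 1 to compound 2 (0.13 log units; within the scatter) is within the scatter, so the two compounds cannot be separated on this read-out.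

Compound 3 `CCCCCCCCS(=O)(=O)Nc1ccc(/C=C/c2ccccc2)cc1C(=O)O` is the next member. It differs from compound 2 in one place: 2-phenylethenyl in place of 3-fluorophenyl on an aromatic carbon. Among the measured compounds shown here, none of the measured steps covers this change, since the only step recorded, from compound 1 to compound 2, exchanges one aryl group for another and stays within the scatter. For the measured compounds named here, with no measured step bearing on the change, and both measured compounds lying close together, no step beyond the scatter is expected in this assay for compound 3.

Compound 3 is therefore estimated at 30000 nM, with a range from 9000 nM to 100000 nM. The expected step is a 1.3-fold lower number from compound 2 to compound 3 (0.10 log units; within the scatter).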

Compound 3, half-maximal inhibitory concentration: 16300 nM
Estimate against measurement, compound 3: 1.8-fold (0.26 log units) above, within the range that was stated.
By their numbers in this assay, from the lowest: compounds 3, 1 and 2 (each within the scatter of the next, the first and the last beyond it).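

At this position, para to a large group and meta to a carboxy group, the series now has its first step beyond the scatter in this assay: 2-phenylethenyl in place of 3-fluorophenyl gives a 2.3-fold lower number from compound 2 to compound 3 (0.36 log units; beyond the scatter). Against 2-methoxyphenyl the same group gives a 1.7-fold lower number from compound 1 to compound 3 (0.23 log units; within the scatter), so it separates from only one of the two aryl groups, and a group with a double bond outside the aromatic ring is accepted here on a level with 2-methoxyphenyl. No measurement at hand bears on the reason for the modest step.

Whether the double bond itself matters stays open, since the saturated counterpart, 2-phenylethyl, is not among the compounds shown. Also open, as far as these compounds go, is how an unsubstituted phenyl or an aminophenyl would read at this position.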